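Three Limits and a Fourth Compound Still to Measure

The compounds below may be only part of what the source reports. "The series", "measured", "known", "first", "only" and "open" are said of these compounds alone.

Compound 1 `O=C(/C=C/c1ccc(OCCCCCO[N+](=O)[O-])c(O)c1)OCCCCCO[N+](=O)[O-]`: in a functional assay on H266 cells (Homo sapiens) for cytotoxicity, read by resazurin assay, with a stated time of 72 h (on this read-out higher numbers stand for weaker inhibition and lower numbers for stronger inhibition), compound 1 gives > 50000 nM, which is a limit of the assay and not a number.
Compound 2 `COc1cc(/C=C/C(=O)OCCCO[N+](=O)[O-])ccc1OCCCO[N+](=O)[O-]`: in this assay compound 2 gives > 50000 nM, again a limit.
Compound 3 `COc1cc(/C=C/C(=O)OCCCCCO[N+](=O)[O-])ccc1OCCCCCO[N+](=O)[O-]`: in this assay compound 3 gives > 50000 nM, again a limit.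

All three measured compounds sit at the same point, (the limit of > 50000 nM in this assay, at which 3 of the 3 values shown sit), so none of them shows a readable number. Compound 3 and compound 1 differ in one place only: hydrogen in place of methyl on an oxygen on an aromatic ring. The step that the two limits leave unreadable from compound 3 to compound 1 therefore has no size that can be read, since both of its ends are limits. How compound 2 and compound 3 differ from each other is not broken down here.

Compound 4 `O=C(/C=C/c1ccc(OCCCO[N+](=O)[O-])c(O)c1)OCCCO[N+](=O)[O-]` has not yet been measured. It differs from compound 2 by hydrogen in place of methyl on an oxygen on an aromatic ring, and this is the same change as that from compound 3 to compound 1, made at the same kind of place on the ring. Going by the values given here, the only guide is that compound 3 stands at > 50000 nM and compound 1 at > 50000 nM, both limits. On that basis the step from compound 2 to compound 4 is expected to be a step that the limit leaves unreadable from compound 2 to compound 4, that is, no readable change. Compound 4 is accordingly expected to give about 100000 nM, most likely reported as a limit again, with a plausible range from 40000 nM to 400000 nM.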

Compound 4, half-maximal inhibitory concentration: > 50000 nM
Compound 4 was reported as a limit (the forecaster's own chance of this, stated with the estimate: 85%); the middle value is on the limit's open side.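

Compound 2 and compound 4 both stand at a limit of the assay and not at a number, so no size can be read for the change from methoxy to hydroxy between them: the limit of > 50000 nM in this assay, at which 4 of the 4 values shown sit.

The compounds shown leave open whether this change has any effect in this assay, and at what concentration, if any, each of the four compounds would reach half-maximal inhibition.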